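A few compounds are considered here, and "the series" means these few. Any claim that something is new, unique, unknown or untested is made for them only; others in the source may bear on it.

Three compounds built on one shared core have been run in an ADME assay on microsomes from liver (Homo sapiens) for metabolic stability, read by LC-MS, using NADPH, with stated times of 5 min and 30 min, tested at 1 uM; a lower number here means slower removal, a higher number faster removal of the compound. Compound 1 `O=C1CCCN1c1cnc(NCc2c(F)ccc3c2CCO3)n2cnnc12` carries a 2-oxopyrrolidin-1-yl group and in this assay reaches only the limit of < 3 mL.min-1.g-1, a bound rather than a number. Compound 2 `Fc1ccc2c(c1CNc1ncc(Oc3ccccc3)c3nncn13)CCO2` carries a phenoxy group in its place and gives 18 mL.min-1.g-1. Compound 3 `Fc1ccc2c(c1CNc1ncc(Nc3ccccc3)c3nncn13)CCO2` carries an anilino group and gives 20 mL.min-1.g-1; its gap to compound 2, a 1.1-fold higher number from compound 2 to compound 3 (0.05 log units; within the scatter), is within the scatter, whereas an at least 6.0-fold higher number from compound 1 to compound 2 (0.77 log units; beyond the scatter) and an at least 6.6-fold higher number from compound 1 to compound 3 (0.82 log units; beyond the scatter) are beyond it. Compound 4 `COCCC(=O)Nc1cnc(NCc2c(F)ccc3c2CCO3)n2cnnc12` differs from compound 3 by (2-methoxyethyl)carbonyl in place of phenyl on a nitrogen on an aromatic ring. The step that bears on this most is an at least 6.6-fold higher number from compound 1 to compound 3 (0.82 log units; beyond the scatter), which exchanged a carbonyl-bearing ring on the same nitrogen for anilino. Compound 4 is therefore expected to move back toward compound 1, by an estimated 4.0-fold lower number from compound 3 to compound 4 (0.60 log units; beyond the scatter). Compound 4 is estimated at 5 mL.min-1.g-1, within 2 mL.min-1.g-1 to 12 mL.min-1.g-1.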

Compound 4, intrinsic clearance in microsomes: < 3 mL.min-1.g-1
Compound 4: no number, only a limit; the forecaster's own chance of this, stated with the estimate: 30%; at least 1.6-fold (0.22 log units) between middle value and limit.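

In this assay, (2-methoxyethyl)carbonyl in place of phenyl on the nitrogen gives an at least 6.6-fold lower number from compound 3 to compound 4 (0.82 log units; beyond the scatter), and ((2-methoxyethyl)carbonyl)amino in place of phenoxy gives an at least 6.0-fold lower number from compound 2 to compound 4 (0.77 log units; beyond the scatter). The value of compound 4, < 3 mL.min-1.g-1, is a limit and not a number. An open chain with a carbonyl thus reads like the ring of compound 1, though the step between them cannot be read because both values are limits: the limit of < 3 mL.min-1.g-1 in this assay, at which 2 of the 4 values shown sit.

The compounds shown leave open whether the carbonyl matters or only the loss of the phenyl. A benzoyl group or a plain ethyl chain on this nitrogen would separate the two.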